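Swapping a benzyl substituent and watching cell tolerance

A few compounds are considered here, and "the series" means these few. Any claim that something is new, unique, unknown or untested is made for them only; others in the source may bear on it.

Compound 1, `N#Cc1ccccc1COc1cc(O)c2c(=O)c(O)c(-c3ccccc3)oc2c1`, carries a 2-cyanobenzyl group on the shared core. In an ADME assay on Huh-5-2 cells (Homo sapiens) for cytotoxicity, read by WST assay, with a stated time of 3 days (a higher number here means that more compound is tolerated, a lower number that less compound is tolerated), compound 1 gives 22000 nM. Among the measured compounds shown here, this is the only plain number among the values at hand. Compound 2, `COc1ccccc1COc1cc(O)c2c(=O)c(O)c(-c3ccccc3)oc2c1`, carries a methoxy group where compound 1 carries the cyano group; in this assay compound 2 reaches only the limit of > 100000 nM. Read as a step, there is an at least 4.5-fold higher number from compound 1 to compound 2 (0.65 log units; beyond the scatter), so exchanging the cyano group for a methoxy group let the cells tolerate more compound, though the true size of that gain is hidden because of the limit of > 100000 nM in this assay, at which 1 of the 2 values shown sits. Compound 3, `O=c1c(O)c(-c2ccccc2)oc2cc(OCc3cccc([N+](=O)[O-])c3)cc(O)c12`, is the compound still to be measured: 3-nitrophenyl in place of 2-cyanophenyl on a saturated chain carbon bound to an oxygen on an aromatic ring. For the measured compounds named here, the single measured step that bears on this change is the methoxy exchange just described, which moved tolerance upward by at least a modest amount. A 3-nitrophenyl group is a different replacement from a methoxy group, so only a small upward shift, if any beyond the scatter, is expected here. Compound 3 is expected to give 40000 nM, with a range from 15000 nM to 100000 nM. That estimate means an expected step of a 1.8-fold higher number from compound 1 to compound 3 (0.26 log units; within the scatter).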

Compound 3, half-maximal cytotoxic concentration: 76000 nM
Compound 3: the middle estimate sits 1.9-fold (0.28 log units) below what was measured; low and high end bracket the measured number.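

In this assay, the change from 2-cyanobenzyl to 3-nitrobenzyl gives a 3.5-fold higher number from compound 1 to compound 3 (0.54 log units; beyond the scatter). The earlier step showed that one replacement of the 2-cyanophenyl group raised the tolerated concentration, and this result shows that a second, quite different replacement does the same, leaving compound 1 as the least tolerated of the three. Against the methoxy compound the step reads an at least 1.3-fold lower number from compound 2 to compound 3 (0.11 log units; that floor lies within the scatter), and no order between these two can be claimed, because compound 2 stands at a limit of the assay rather than at a number: the limit of > 100000 nM in this assay, at which 1 of the 3 values shown sits.

The change to compound 3 alters both the group and the number in its name, so these compounds cannot tell whether the higher value comes from the nitro group itself or from where it sits; a 3-cyanobenzyl or a 2-nitrobenzyl group would separate the two. As far as these compounds go, it also remains open whether the tolerance seen here extends to quite different groups on the benzyl ring, such as an amine or a carboxylic acid.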